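The source may hold more compounds than are shown below. What is called first, only, known or untested is meant among the compounds shown, and "the series" means these compounds.

The study concerns a small set of compounds tested in a functional assay on the whole organism (Abdomen, strain Swiss) for inhibition, with Mus musculus as the target, with stated times of 30 min, 10 min and 5 min, at a dose of 40 mg/kg by the oral route; a higher number here means a stronger effect of the compound at the dose given, a lower number a weaker effect. Compound 1 `CC/C=C/c1c(C)nn(CCCN2CCN(c3ccc(C)cc3)CC2)c(=O)c1N` gives 45% in this assay. Compound 2 `CC(=O)c1cccn1CCCN1CCN(c2ccc(F)cc2)CC1` gives 38%, and compound 3 `CC(=O)c1cccn1CCCN1CCN(c2cccc(Cl)c2)CC1` gives 54%. Among the three numbers compound 3 stands highest, but its gap to compound 1 lies within the scatter, so no order between those two can be stated; only its gap to compound 2 lies beyond the scatter. Among the measured compounds shown here, the one step between two measured compounds that differ in a single place is a number 16 percentage points higher from compound 2 to compound 3 (beyond the scatter), a modest step.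

Compound 4 `COc1cccc(N2CCN(CCCn3cccc3C(C)=O)CC2)c1` has not yet been measured. It differs from compound 3 in one place: methoxy in place of chloro on an aromatic carbon. The step from compound 2 to compound 3 bears on this change only loosely: it also altered the group on the phenyl ring attached to the amine nitrogen in the ring, but it exchanged 4-fluorophenyl for 3-chlorophenyl, whereas here methoxy replaces chloro on the same aromatic carbon. For the measured compounds named here, no measured step exchanges chloro for methoxy. A step of no more than the scatter is therefore expected in this assay, most likely a small decrease, a number 8 percentage points lower from compound 3 to compound 4 (within the scatter). Compound 4 is accordingly estimated at 46%, with a range from 30% to 62%.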

Compound 4, a percentage reported as inhibition, in the whole organism at one dose (the size of the read-out at that dose, not a potency): 52%
Compound 4: middle estimate off by 6 percentage points, on the low side; low and high end bracket the measured number.
By their numbers in this assay, from the lowest: compounds 2, 1, 4 and 3 (each within the scatter of the next, the first and the last beyond it).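

In this assay methoxy in place of chloro on an aromatic carbon, meta to a large group, gives a number 2 percentage points lower from compound 3 to compound 4 (within the scatter) and so the two groups cannot be told apart at this place, although methoxy brings one more heavy atom and one hydrogen-bond acceptor. The result also shows that the higher number relative to compound 2 is not confined to the 3-chlorophenyl group: 3-methoxyphenyl in place of 4-fluorophenyl gives a number 14 percentage points higher from compound 2 to compound 4 (beyond the scatter) and 3-chlorophenyl in place of 4-fluorophenyl gives a number 16 percentage points higher from compound 2 to compound 3 (beyond the scatter) in the same assay. No measurement in hand explains why the exchange of chloro for methoxy leaves the read-out within the scatter.

Going by these compounds, how much of the step from compound 2 belongs to the place of the group on the phenyl ring and how much to the group itself stays open, as both change together in each of these steps. Also open, on these data alone, is how an amine, a carboxylic acid or a longer chain such as ethoxy on this same aromatic carbon would read at this dose.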